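Fluoro to trifluoromethyl: what three compounds can suggest

The compounds below may be only part of what the source reports. "The series", "measured", "known", "first", "only" and "open" are said of these compounds alone.

Of the compounds shown here, three with a shared core have been tested in a functional assay on HepG2 cells (Homo sapiens) for cytotoxicity, read by MTT assay, with a stated time of 24 h; on this read-out higher numbers stand for weaker inhibition and lower numbers for stronger inhibition. Compound 1 `O=C1/C(=C/c2cccnc2)CN(S(=O)(=O)c2ccc(C(F)(F)F)cc2)C/C1=C\c1ccccc1F` gives 2400 nM, compound 2 `O=C1/C(=C/c2cccnc2)CN(S(=O)(=O)c2ccc(Br)cc2)C/C1=C\c1ccccc1F` gives 8700 nM and compound 3 `CC(=O)Nc1ccc(S(=O)(=O)N2C/C(=C\c3cccnc3)C(=O)/C(=C/c3ccccc3F)C2)cc1` gives 4560 nM. They differ in a single group, which is trifluoromethyl, bromo or acetamido.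

Two steps fix the standing of compound 2. One is a 3.6-fold higher number from compound 1 to compound 2 (0.56 log units; beyond the scatter), and the other is a 1.9-fold lower number from compound 2 to compound 3 (0.28 log units; within the scatter). Compound 2 is therefore clearly separated from compound 1 but cannot be told apart from compound 3. The remaining step, a 1.9-fold higher number from compound 1 to compound 3 (0.28 log units; within the scatter), also stays within the scatter.

Compound 4 `O=C1/C(=C/c2cccnc2)CN(S(=O)(=O)c2ccc(Br)cc2)C/C1=C\c1ccccc1C(F)(F)F` keeps the bromo group of compound 2 and changes another part of the molecule: trifluoromethyl in place of fluoro on an aromatic carbon. In words, trifluoromethyl takes the place of fluoro on an aromatic carbon, turning 2-fluorophenyl into 2-(trifluoromethyl)phenyl.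

Among the compounds with values here, no measured step makes this change at this place. The nearest hint is the modest 3.6-fold higher number from compound 1 to compound 2 (0.56 log units; beyond the scatter), which involves trifluoromethyl at a different place and so bears on this change only weakly. A small shift towards a lower number is expected, with a 1.6-fold lower number from compound 2 to compound 4 (0.20 log units; within the scatter) as the estimated step, and no shift at all would be unsurprising. For compound 4 the estimated value is 5500 nM, with an expected range from 2000 nM to 15000 nM.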

Compound 4, half-maximal inhibitory concentration: 2730 nM
Compound 4: the middle estimate sits 2.0-fold (0.30 log units) above what was measured; low and high end bracket the measured number.
By their numbers in this assay, from the lowest: compounds 1, 4, 3 and 2 (each within the scatter of the next, the first and the last beyond it).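

This position responds to change. In this assay there is a 3.2-fold lower number from compound 2 to compound 4 (0.50 log units; beyond the scatter), a modest shift towards stronger inhibition that lies beyond the usual scatter, when 2-fluorophenyl becomes 2-(trifluoromethyl)phenyl with the bromo group held fixed. Within the data shown here, the earlier compounds varied only the group at the other end of the molecule, so this is the first direct sign that the substituent ortho to a large group on this aromatic ring also affects the read-out. No accompanying measurement explains the step, which therefore stands as an observation and not as an account of how the change acts.

This single pair cannot show whether the same exchange would lower the number when the bromo group is replaced by the trifluoromethyl of compound 1 or the acetamido of compound 3. It also leaves open whether the shift follows from trifluoromethyl specifically, since the compounds shown do not include other groups at this place, such as chloro, methoxy or an amine, or a ring with this position left with only hydrogen.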